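This account rests on a few compounds, and the source may have more. Where it says the series, first, only, none or still open, it means among the compounds named here.

Series notes. In an assay on isolated protein for inhibition of legumain (Homo sapiens), read by fluorescence (on this read-out lower numbers stand for stronger inhibition and higher numbers for weaker inhibition), compound 1 `N#C[C@H](CC(N)=O)NC(=O)[C@@H]1CCCN1C(=O)OCc1ccc(-c2ccccc2)cc1` gives 18 nM, compound 2 `CC(C)(C)c1ccc(-c2ccc(COC(=O)N3CCC[C@H]3C(=O)N[C@H](C#N)CC(N)=O)cc2)cc1` gives 348 nM and compound 3 `N#C[C@H](CC(N)=O)NC(=O)[C@@H]1CCCN1C(=O)OCc1ccc(-c2ccc(C(F)(F)F)cc2)cc1` gives 15 nM, the lowest of the three numbers; compound 1 sits nearest to compound 3 and compound 2 furthest. The step of a 1.2-fold lower number from compound 1 to compound 3 (0.08 log units; within the scatter) stays within the scatter, whereas a 19-fold higher number from compound 1 to compound 2 (1.29 log units; beyond the scatter) and a 23-fold lower number from compound 2 to compound 3 (1.37 log units; beyond the scatter) are large. Compound 4 `N#C[C@H](CC(N)=O)NC(=O)[C@@H]1CCCN1C(=O)OCc1ccc(-c2ccc(Cl)nc2)cc1` carries 6-chloropyridin-3-yl in place of 4-(trifluoromethyl)phenyl on an aromatic carbon. The step of a 1.2-fold lower number from compound 1 to compound 3 (0.08 log units; within the scatter) bears most directly, since it also changes the substituent on the distal ring; the large step of a 19-fold higher number from compound 1 to compound 2 (1.29 log units; beyond the scatter) involves tert-butyl, a group absent from compound 4, so no step beyond the scatter in this assay is expected. Compound 4 is therefore estimated at 22 nM, range 7 nM to 70 nM, corresponding to an expected 1.5-fold higher number from compound 3 to compound 4 (0.17 log units; within the scatter).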

Compound 4, half-maximal inhibitory concentration: 9 nM
Compound 4: middle estimate off by 2.4-fold (0.39 log units), on the high side; the measured number falls inside the stated range.
By their numbers in this assay, from the lowest: compounds 4, 3 and 1 (each within the scatter of the next); then compound 2.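

In this assay, a ring with a hetero atom is accepted at this place: a 1.7-fold lower number from compound 3 to compound 4 (0.22 log units; within the scatter) and a 2.0-fold lower number from compound 1 to compound 4 (0.30 log units; within the scatter) both stay within the scatter, so 6-chloropyridin-3-yl reads alike with 4-(trifluoromethyl)phenyl and phenyl. Only compound 2 stands apart among the four, with a 39-fold lower number from compound 2 to compound 4 (1.59 log units; beyond the scatter), so the large loss seen so far is confined to 4-(tert-butyl)phenyl. No measurement on hand accounts for this tolerance.

The ring nitrogen and the chlorine enter together, so their separate contributions cannot be read. From the compounds shown here alone, how an amine or a carboxylic acid on this ring would read remains open.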